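Swapping the Amine Side Chain for an Azetidine Amide

The compounds below may be only part of what the source reports. "The series", "measured", "known", "first", "only" and "open" are said of these compounds alone.

Of the compounds shown here, two sharing one core have so far been measured in a functional assay on MCF7 cells (Homo sapiens) for antiproliferative activity, read by CCK-8 assay, with a stated time of 48 h (on this read-out lower numbers stand for stronger inhibition and higher numbers for weaker inhibition), on this series. Compound 1 (`C=CC(=O)NCCOc1ccc(Oc2c(-c3ccc(F)cc3)sc3cc(O)ccc23)cc1`) gives 23000 nM in that test, and compound 2 (`CNC(=O)/C=C/CNCCOc1ccc(Oc2c(-c3ccc(F)cc3)sc3cc(O)ccc23)cc1`) gives 16100 nM on the same read-out. The two numbers lie within the scatter of each other, so compound 2 stands together with compound 1 and no order can be read between them.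

The next structure is compound 3 (`O=C(CCCNCCOc1ccc(Oc2c(-c3ccc(F)cc3)sc3cc(O)ccc23)cc1)N1CCC1`). It carries 2-((azetidin-1-yl)carbonyl)ethyl in place of 2-(methylcarbamoyl)ethenyl on a saturated chain carbon bound to an amine nitrogen. Within the data shown here, only one measured step bears on this, a replacement of the group on the same amine nitrogen: a 1.4-fold lower number from compound 1 to compound 2 (0.15 log units; within the scatter) in this assay and thus no shift beyond the scatter. Among the measured compounds shown here, one step is thin evidence, and no measured compound carries the azetidine ring. Even so, the expected step is a 1.1-fold higher number from compound 2 to compound 3 (0.02 log units; within the scatter) with no real shift in either direction anticipated. For compound 3 the estimated value is 17000 nM and the expected range runs from 7000 nM to 40000 nM on present evidence.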

Compound 3, half-maximal inhibitory concentration: > 25000 nM
Compound 3 ended at the assay's limit; the forecaster's own chance of this, stated with the estimate: 10%; at least 1.4-fold (0.16 log units) between middle value and limit.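

In this assay compound 3 gives > 25000 nM, which is a limit of the assay and not a number: the limit of > 25000 nM in this assay, at which 1 of the 3 values shown sits. Replacing 2-(methylcarbamoyl)ethenyl with 2-((azetidin-1-yl)carbonyl)ethyl on a saturated chain carbon bound to an amine nitrogen comes out as an at least 1.5-fold higher number from compound 2 to compound 3 (0.19 log units; that floor lies within the scatter), and the wider replacement on the amine nitrogen reads as an at least 1.0-fold higher number from compound 1 to compound 3 (0.03 log units; that floor lies within the scatter). Neither floor passes the scatter, so no real shift can be claimed for this change, but the azetidine amide, which has no hydrogen-bond donor in the entering group, gives this position a reading without a number, something neither earlier compound did.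

The change removes the chain double bond and brings in the four-membered ring at once, and only a saturated chain ending in the methyl amide would tell these two parts apart. On these data alone, it also remains open whether a piperidine amide or a carboxylic acid at the end of the chain would give a value inside the range of the assay.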